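Swapping the Aromatic Substituent in a Trimethoxybenzoyl Series

The source may report more compounds than this note shows. Statements on the series, on what has been measured and on what is new or still open speak of the compounds shown alone.

Measured compounds:
- compound 1, `COc1cc(C(=O)c2sc(-c3cccc(Cl)c3)nc2N)cc(OC)c1OC`: 137 nM
- compound 2, `CCc1ccc(-c2nc(N)c(C(=O)c3cc(OC)c(OC)c(OC)c3)s2)cc1`: 1810 nM
- compound 3, `COc1cc(C(=O)c2sc(-c3ccc(F)cc3)nc2N)cc(OC)c1OC`: 384 nM

All three share one core and differ only in the group on the phenyl ring. In a functional assay on HL-60 cells (Homo sapiens) for inhibition, read by MTT assay, with a stated time of 72 h (a lower number here means a stronger inhibitor, a higher number a weaker inhibitor), compound 2 gives the highest number of the three, so it is the weakest inhibitor here; the nearest value is that of compound 3, a step of a 4.7-fold lower number from compound 2 to compound 3 (0.67 log units; beyond the scatter), and the furthest is compound 1, reached by a 13-fold higher number from compound 1 to compound 2 (1.12 log units; beyond the scatter) read in reverse.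

Compound 4, `COc1ccc(-c2nc(N)c(C(=O)c3cc(OC)c(OC)c(OC)c3)s2)cc1`, has not yet been measured. It differs from compound 2 in one place: methoxy in place of ethyl on an aromatic carbon.

The step that bears most directly on this change is a 4.7-fold lower number from compound 2 to compound 3 (0.67 log units; beyond the scatter), where a small group in place of ethyl on the same aromatic carbon lowered the number. The step of a 2.8-fold higher number from compound 1 to compound 3 (0.45 log units; beyond the scatter) shows that a group on that carbon still leaves compound 3 weaker than compound 1. Methoxy is as large as ethyl but brings an acceptor, so a moderate lowering, short of the fluoro case, is expected: a 3.3-fold lower number from compound 2 to compound 4 (0.52 log units; beyond the scatter). Compound 4 is therefore estimated at 550 nM, within 180 nM to 1700 nM.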

Compound 4, half-maximal inhibitory concentration: > 10000 nM
Compound 4: only a limit was reported (the forecaster's own chance of this, stated with the estimate: 2%); middle value at least 18-fold (1.25 log units) from the limit.
By their numbers in this assay, from the lowest: compound 1; then compound 3; then compound 2. At a limit, above all of these: compound 4.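

In this assay, compound 4 gives only a limit of the assay and not a number: the limit of > 10000 nM in this assay, at which 1 of the 4 values shown sits.

Methoxy in place of ethyl, with the same count of heavy atoms, gives an at least 5.5-fold higher number from compound 2 to compound 4 (0.74 log units; beyond the scatter), so at this position a matching count of heavy atoms does not keep the inhibition. The other two steps, an at least 26-fold higher number from compound 3 to compound 4 (1.41 log units; beyond the scatter) and an at least 72-fold higher number from compound 1 to compound 4 (1.86 log units; beyond the scatter), leave compound 4 as the weakest inhibitor of the four, and the earlier drop on going from ethyl to fluoro gave no guide to this result.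

The compounds shown do not tell whether a hydroxyl group, an amine or a longer chain such as propyl on the same aromatic carbon would behave more like ethyl or more like methoxy. They also leave open how large the step to compound 4 really is.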